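A few compounds are considered here, and "the series" means these few. Any claim that something is new, unique, unknown or untested is made for them only; others in the source may bear on it.

Measured compounds:
- compound 1 `CC(C)NC(=O)c1ccc(-c2cnn3c(NCC4CCOCC4)nc(OC4CCCC4)nc23)cc1`, "not determined" (no result reported) in a functional assay on OVCAR-3 cells (Homo sapiens) for antiproliferative activity; a lower number here means a stronger inhibitor of growth, a higher number a weaker inhibitor of growth
- compound 2 `Cc1cc(-c2cnn3c(NCC4CCOCC4)nc(Nc4ccccc4)nc23)ccc1C(=O)NC1CC1`, 1700 nM in this assay
- compound 3 `CC(=O)Nc1cccc(Oc2nc(NCC3CCOCC3)n3ncc(-c4ccc(C(=O)NC5CC5)c(C)c4)c3n2)c1`, 1200 nM in this assay

Compound 3 holds the lower of the two numbers available in this assay, but its nearest neighbour, compound 2, sits close: a 1.4-fold lower number from compound 2 to compound 3 (0.15 log units; within the scatter), which is inside the scatter, so the two cannot be ranked. Compound 1 adds nothing here, as no number was obtained for it.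

Compound 4 `Cc1cc(-c2cnn3c(NCC4CCOCC4)nc(Nc4cccc(F)c4)nc23)ccc1C(=O)NC1CC1` arises from compound 3 by a single change: (3-fluorophenyl)amino in place of 3-acetamidophenoxy on an aromatic carbon. Among the measured compounds shown here, only one measured step bears on this change. Going from compound 2 to compound 3 replaced an anilino group at the same carbon with 3-acetamidophenoxy and moved the number by a 1.4-fold lower number from compound 2 to compound 3 (0.15 log units; within the scatter), a shift that did not exceed the scatter. For the measured compounds named here, the new change runs largely back in the opposite direction, restoring an anilino group that now carries a fluorine, and the fluorine itself has no precedent among the measured compounds. The expected step in this assay is therefore small, a 1.3-fold higher number from compound 3 to compound 4 (0.10 log units; within the scatter), with no direction that can be claimed beyond the scatter. Compound 4 is estimated to give 1500 nM in this assay, within a range from 500 nM to 4500 nM.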

Compound 4, concentration for 50% growth inhibition: 58 nM
Compound 4: middle estimate off by 26-fold (1.41 log units), on the high side; measured number outside the range, below it.
By their numbers in this assay, from the lowest: compound 4; then compounds 3 and 2 (each within the scatter of the next).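

At the aromatic carbon between two ring nitrogen atoms, the earlier pair had suggested a position that tolerates exchange without much consequence in this assay, since the change from anilino to 3-acetamidophenoxy gave only a 1.4-fold lower number from compound 2 to compound 3 (0.15 log units; within the scatter) and left the two compounds unranked. Compound 4 overturns that reading: fluoro in place of hydrogen on the anilino ring gives a 29-fold lower number from compound 2 to compound 4 (1.47 log units; beyond the scatter), and (3-fluorophenyl)amino in place of 3-acetamidophenoxy gives a 21-fold lower number from compound 3 to compound 4 (1.32 log units; beyond the scatter), so a single fluorine on the anilino ring separates compound 4 from both neighbours, and the substituent at this carbon matters far more than the first step showed. No measurement in hand accounts for the size of these steps.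

As far as these compounds go, it remains open whether the gain belongs to fluorine specifically or would also appear with chloro, methyl or nitrile on that ring, and whether it depends on where on the ring the fluorine sits. A 3-fluorophenoxy group at the same carbon would show whether the gain also depends on the linking amine nitrogen, which the compounds shown cannot separate from the effect of the fluorine.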